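Nitro in place of hydrogen on compound 1

The source may hold more compounds than are shown below. What is called first, only, known or untested is meant among the compounds shown, and "the series" means these compounds.

Compound 1 `O=C(CCCCC(S)CCS)Nc1ccccc1` gives 1.32% in a functional assay on Bel-7402 cells (Homo sapiens) for inhibition, read by MTT assay, with a stated time of 24 h, tested at 1 ug/mL; a higher number here means more inhibition of growth at the concentration tested, a lower number less inhibition of growth. Compound 2 `O=C(CCCCC(S)CCS)Nc1ccccc1Cl` gives 3.08% in this assay. Going by the values given here, these two values lie within the scatter of each other, and compound 1 therefore stands level with the only other measured compound.

Compound 3 `O=C(CCCCC(S)CCS)Nc1ccc([N+](=O)[O-])cc1` has not been measured. Its structural change is nitro in place of hydrogen on an aromatic carbon, which places nitro in place of hydrogen on an aromatic carbon, para to a large group.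

Among the compounds with values here, only one measured step bears on this change, the chloro in place of hydrogen: a number 1.8 percentage points higher from compound 1 to compound 2 (within the scatter). Within the data shown here, that step stays within the scatter, but it involves chloro, and no measured compound yet carries nitro. The guide is therefore weak, and no shift beyond the scatter is expected in this assay.

The estimated step is a number 2.7 percentage points higher from compound 1 to compound 3 (within the scatter). For compound 3 the expected value is 4%, with an estimated range of 0% to 15%.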

Compound 3, percent growth inhibition at one concentration: 1.73%
Beside the measured number, compound 3's estimate is 2.3 percentage points above it, and the stated range covers the measured number.
By their numbers in this assay, from the lowest: compounds 1, 3 and 2 (each within the scatter of the next).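

In this assay, nitro in place of hydrogen, para to a large group, gives a number 0.4 percentage points higher from compound 1 to compound 3 (within the scatter), so this position on the aromatic ring accepts a group of 3 heavy atoms with the number staying within the scatter. Alongside a number 1.8 percentage points higher from compound 1 to compound 2 (within the scatter), this means that neither aromatic substitution tested so far, chloro or nitro, separates from compound 1 in this read-out. No measurement available here bears on the reason for this result.

From the compounds shown here alone, whether an amine or a carboxylic acid at this same position would give a step beyond the scatter remains open. Also open, going by these compounds, is whether a change away from the aromatic ring, such as a longer chain in the core of compound 1, would lift the number clear of this narrow band.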